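Swapping an Aromatic Acyl Group for an Octyl Chain

A few compounds are considered here, and "the series" means these few. Any claim that something is new, unique, unknown or untested is made for them only; others in the source may bear on it.

Compound 1 `O=C(Nc1ccccc1O)C1CCc2ccccc2N1C(=O)c1ccccc1Cl` gives 44900 nM
Compound 2 `CCCC(=O)N1c2ccccc2CCC1C(=O)Nc1cc(C(F)(F)F)cc(C(F)(F)F)c1` gives 21900 nM
Compound 3 `O=C(Nc1ccccc1C(F)(F)F)C1CCc2ccccc2N1C(=O)c1ccccc1` gives 6500 nM

All three compounds were tested in a functional assay on HCT-15 cells (Homo sapiens) for cytotoxicity, read by sulforhodamine B assay, with a stated time of 72 h (on this read-out higher numbers stand for weaker inhibition of growth and lower numbers for stronger inhibition of growth), and compound 1 stands at the highest number of the set. Its gaps to compound 2 and compound 3 both lie beyond the scatter, so it is the weakest of the three.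

Compound 4 `CCCCCCCCC(=O)N1c2ccccc2CCC1C(=O)Nc1ccccc1O` differs from compound 1 by octyl in place of 2-chlorophenyl on a carbonyl carbon. Among the measured compounds shown here, no two measured compounds differ in one place only, so the data give no direct measure of this change. Compound 2 (21900 nM) also has an open chain on that carbonyl carbon, though its other amide group differs too. A modest step towards a lower number, meaning stronger growth inhibition, is therefore expected in this assay. The expected change is a 2.2-fold lower number from compound 1 to compound 4 (0.35 log units; beyond the scatter) on this evidence. Compound 4 is estimated at 20000 nM with an expected range from 7000 nM to 55000 nM in this measurement.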

Compound 4, concentration for 50% growth inhibition: 38400 nM
Compound 4: middle estimate off by 1.9-fold (0.28 log units), on the low side; low and high end bracket the measured number.
By their numbers in this assay, from the lowest: compound 3; then compounds 2, 4 and 1 (each within the scatter of the next, the first and the last beyond it).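

Octyl in place of 2-chlorophenyl on a carbonyl carbon gives a 1.2-fold lower number from compound 1 to compound 4 (0.07 log units; within the scatter) in this assay. Among the compounds shown here, this is the first comparison in the set that changes one place only, and it shows that, with the rest of compound 1 held constant, an open chain and a six-membered aromatic ring on this carbonyl carbon cannot be told apart on this read-out. No measurement on hand bears on this result.

The compounds shown leave open whether a carboxylic acid or an amine at the end of the chain, or a longer chain, would separate from octyl at this position. They also leave open whether octyl and 2-chlorophenyl would still read alike with the other amide group of compound 2 or compound 3 in place.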